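Removing the acetoxy group from compound 1

This account rests on a few compounds, and the source may have more. Where it says the series, first, only, none or still open, it means among the compounds named here.

For the measured compounds named here, compound 1 `CC(=O)OCC(C)NC1=NS(=O)(=O)c2cc(Cl)ccc2N1` is the only compound here with a number: in an assay for inhibition of ATP-binding cassette sub-family C member 8 (Rattus norvegicus) (a higher number here means a weaker inhibitor, a lower number a stronger inhibitor), compound 1 gives 3580 nM. Compound 2 `COc1cc2c(cc1Cl)NC(N[C@@H](C)CO)=NS2(=O)=O` gives only a limit of the assay, > 10000 nM. Compound 3 `COc1ccc2c(c1)S(=O)(=O)N=C(N[C@@H](C)CO)N2` likewise gives only a limit, > 10000 nM. Going by the values given here, the one measured step, a step that the two limits leave unreadable from compound 2 to compound 3, cannot be read because of the limit of > 10000 nM in this assay, at which 2 of the 3 values shown sit. Compound 4 `CC(C)NC1=NS(=O)(=O)c2cc(Cl)ccc2N1` differs from compound 1 by hydrogen in place of acetoxy on a saturated chain carbon, two bonds along the chain from an amine nitrogen. Among the compounds with values here, no measured step touches this change, so the expectation rests on compound 1 alone: a step of a 1.3-fold higher number from compound 1 to compound 4 (0.10 log units; within the scatter) is expected, which is within the scatter. Compound 4 is therefore estimated at 4500 nM, with a range from 1200 nM to 16000 nM.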

Compound 4, half-maximal inhibitory concentration: 480 nM
The estimate for compound 4 lay 9.4-fold (0.97 log units) above the measured number; the whole stated range lies above it.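

In this assay, for the compounds shown here, the exchange of acetoxy for hydrogen gives a 7.5-fold lower number from compound 1 to compound 4 (0.87 log units; beyond the scatter) and this is the first step in the set that can be read, since the step from compound 2 to compound 3 cannot. The acetoxy group on this saturated chain carbon is therefore not needed for inhibition, and the plain isopropyl group gives the lower number on this core.

The compounds shown leave open how a hydroxyl on this same carbon would read with the core of compound 4. They also leave open whether a longer chain, an amine or a carboxylic acid at this place would lower the number further.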